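Chlorobenzyl oxime ethers on tumour cells: positional swap

The source may hold more compounds than are shown below. What is called first, only, known or untested is meant among the compounds shown, and "the series" means these compounds.

Compound 1 `Clc1ccc(COc2ccccc2/C=C/C(/C=C/c2ccccn2)=N/Oc2ncnc3cc(Cl)ccc23)c(Cl)c1` gives 23.6% in a functional assay on SMMC-7721 cells (Homo sapiens) for inhibition, read by MTT assay, with a stated time of 72 h, tested at 1 uM; on this read-out higher numbers stand for a stronger effect at the one concentration tested and lower numbers for a weaker effect. Compound 2 `Clc1ccc2c(O/N=C(/C=C/c3ccc(OCc4ccccc4Cl)cc3)\C=C\c3ccccn3)ncnc2c1` gives 18.1% in this assay, the lowest of the three numbers seen, though compound 1 lies within the scatter of it, so no order between the two can be read. Compound 3 `Clc1ccccc1COc1ccccc1/C=C/C(/C=C/c1ccccn1)=N/Oc1ncnc2ccccc12` gives 95.7%, far above compound 2 and beyond the scatter. Compound 3 differs from compound 2 in more than one place, so no single step accounts for that gap.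

Compound 4 `Clc1ccc(COc2ccc(/C=C/C(/C=C/c3ccccn3)=N/Oc3ncnc4cc(Cl)ccc34)cc2)cc1` has not yet been tested in this assay. Against compound 2 the difference is 4-chlorophenyl in place of 2-chlorophenyl on a saturated chain carbon bound to an oxygen on an aromatic ring. Going by the values given here, no measured pair in the set isolates this change, so nothing direct says which way it moves the read-out. Among the compounds with values here, with only one clean comparison unavailable, the step from compound 2 to compound 4 is expected to be small, a number 5.9 percentage points higher from compound 2 to compound 4 (within the scatter), not beyond the scatter in either direction. Compound 4 is therefore estimated at 24%, within 5% to 55%, with the upper end left wide because compound 3 shows that compounds of this shape can reach high inhibition.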

Compound 4, a percentage reported as inhibition, at one concentration (the size of the read-out at that concentration, not a potency): 67.4%
Compound 4: the middle estimate sits 43.4 percentage points below what was measured; measured number above the stated range.
By their numbers in this assay, from the lowest: compounds 2 and 1 (each within the scatter of the next); then compound 4; then compound 3.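

In this assay, 4-chlorophenyl in place of 2-chlorophenyl on a saturated chain carbon bound to an oxygen on an aromatic ring gives a number 49.3 percentage points higher from compound 2 to compound 4 (beyond the scatter). Going by these compounds alone, the two compounds have the same atoms, joined differently, which makes this the first comparison to isolate the chlorine placement on this ring and shows that the read-out is sensitive to that placement alone. No measurement at hand accounts for the size of this step.

As far as these compounds go, whether the step holds with other changes elsewhere on the shared core remains open, and a single concentration says nothing about potency. Also open, from the compounds shown here alone, is how the read-out responds when the chlorine on this ring gives way to another group, such as methoxy or a dimethylamino group.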